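Replacing the cyclopropyl of compound 2

The source may hold more compounds than are shown below. What is called first, only, known or untested is meant among the compounds shown, and "the series" means these compounds.

Measured in a functional assay on A549 cells (Homo sapiens) for cytotoxicity, read by MTT assay, with a stated time of 72 h; a higher number here means a weaker inhibitor, a lower number a stronger inhibitor:
Compound 1 `COc1ncc(-c2ccc3nc(NC(=O)N4CCCC4)nn3c2)cc1NS(=O)(=O)c1ccc(F)cc1` gives 3570 nM
Compound 2 `COc1ncc(-c2ccc3nc(NC(=O)NC4CC4)nn3c2)cc1NS(=O)(=O)c1ccc(F)cc1` gives 210 nM

Compound 2 holds the lower of the two numbers. Compound 3 `COc1ncc(-c2ccc3nc(NC(=O)NCC(=O)N4CCCC4)nn3c2)cc1NS(=O)(=O)c1ccc(F)cc1` carries ((pyrrolidin-1-yl)carbonyl)methyl in place of cyclopropyl on an amide-type nitrogen. Within the data shown here, only one measured step bears on this change, a 17-fold lower number from compound 1 to compound 2 (1.23 log units; beyond the scatter), a large one, with cyclopropylamino in place of pyrrolidin-1-yl on a carbonyl carbon. Compound 3 loses the cyclopropyl and again holds a pyrrolidin-1-yl, and compound 1 with its pyrrolidin-1-yl stands at 3570 nM, so a higher number in this assay is expected, though a smaller rise than that step. The expected step is a 3.8-fold higher number from compound 2 to compound 3 (0.58 log units; beyond the scatter) in size. For compound 3 the estimate is 800 nM, with an expected range of 200 nM to 4000 nM.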

Compound 3, half-maximal inhibitory concentration: 2190 nM
For compound 3 the middle estimate is 2.7-fold (0.44 log units) below the measured one; measured number inside the range.
By their numbers in this assay, from the lowest: compound 2; then compounds 3 and 1 (each within the scatter of the next).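

In this assay, the amide-type nitrogen does not keep its level once cyclopropyl gives way to ((pyrrolidin-1-yl)carbonyl)methyl, with a 10-fold higher number from compound 2 to compound 3 (1.02 log units; beyond the scatter). Set against pyrrolidin-1-yl on the carbonyl carbon, (((pyrrolidin-1-yl)carbonyl)methyl)amino gives a 1.6-fold lower number from compound 1 to compound 3 (0.21 log units; within the scatter), so this longer substituent offers no measurable gain over that group. No measurement given here explains the loss. Going by these compounds, whether it follows the pyrrolidin-1-yl ring or the carbonylmethyl link stays open. A cyclobutyl, a plain methyl or a longer alkyl chain on the same nitrogen would show how narrow the preference for cyclopropyl is.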